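Halogen pattern on the benzamide and maximal response at GPR27

The source may hold more compounds than are shown below. What is called first, only, known or untested is meant among the compounds shown, and "the series" means these compounds.

Compound 1: `O=C(Nc1ccc(S(=O)(=O)Nc2ncccn2)cc1)c1ccc(Cl)cc1Cl` — "not determined" (no result reported)
Compound 2: `O=C(Nc1ccc(S(=O)(=O)Nc2ccccc2)cc1)c1ccc(Cl)cc1Br` — 123%
Compound 3: `O=C(Nc1ccc(S(=O)(=O)Nc2ccccc2)cc1)c1ccc(I)cc1F` — 36%

In a functional assay on HEK293 cells for agonist activity at probable G-protein coupled receptor 27 (Homo sapiens), read by a luciferase reporter and beta-arrestin recruitment, with a stated time of 10 min (on this read-out lower numbers stand for smaller maximal responses and higher numbers for larger maximal responses), compound 2 gives 123%, while compound 3 gives 36%. Compound 1 has no number in this assay, as noted. Compound 3 therefore stands lowest of the two numbers shown, with compound 2 as its only measured neighbour.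

Compound 4, `O=C(Nc1ccc(S(=O)(=O)Nc2ccccc2)cc1)c1ccc(Cl)cc1Cl`, has not been measured. It differs from compound 3 in one place: 2,4-dichlorophenyl in place of 2-fluoro-4-iodophenyl on a carbonyl carbon. Going by the values given here, the only measured step that bears on this position is the one between compound 2 and compound 3, a number 87 percentage points lower from compound 2 to compound 3 (beyond the scatter), which shows that exchanging the halogen pair on the aryl attached to the carbonyl carbon can move the maximal response by a large amount. The 2,4-dichlorophenyl of compound 4 is, in its halogens, closer to the 2-bromo-4-chlorophenyl of compound 2 than to the 2-fluoro-4-iodophenyl of compound 3. Among the compounds with values here, a step upward beyond the scatter is therefore expected, though its full size is uncertain on only one relevant step.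

Compound 4 is estimated to reach 100%, with a range of 55% to 140%, meaning an expected step of a number 64 percentage points higher from compound 3 to compound 4 (beyond the scatter).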

Compound 4, largest response reached (Emax), in percent of the reference or control that the assay uses: 100%
Compound 4: middle estimate and measured number agree at the digits printed, within the range that was stated.
By their numbers in this assay, from the lowest: compound 3; then compound 4; then compound 2.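

In this assay, the earlier step, a number 87 percentage points lower from compound 2 to compound 3 (beyond the scatter), changed both halogens at once, so it could not show how much a single exchange at this position matters. Going by these compounds alone, the new steps separate the two cases: changing only one halogen gives a number 23 percentage points lower from compound 2 to compound 4 (beyond the scatter), a modest step with chloro in place of bromo on an aromatic carbon, whereas a number 64 percentage points higher from compound 3 to compound 4 (beyond the scatter) is a large step with 2,4-dichlorophenyl in place of 2-fluoro-4-iodophenyl on a carbonyl carbon. Among these three compounds, the low maximal response therefore belongs to the 2-fluoro-4-iodophenyl of compound 3, and nothing shown here explains either step.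

The compounds shown leave open whether the fluoro or the iodo accounts for the lower response of compound 3, and whether a methoxy or trifluoromethyl group on this aryl ring would keep the response of the halogens. They also leave open whether the same exchanges carry over to the core of compound 1, which stands at "not determined" (no result reported).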